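This account rests on a few compounds, and the source may have more. Where it says the series, first, only, none or still open, it means among the compounds named here.

Compound 1 `O=C1C=CC(=O)C(c2cc(-c3ccc(C(=O)N4CCC(C(F)(F)F)CC4)s3)on2)=C1`: > 30000 nM
Compound 2 `COc1ccc(OC)c(-c2cc(-c3ccc(C(=O)N4CCC(C(F)(F)F)CC4)s3)on2)c1`: > 30000 nM
Compound 3 `COc1ccc(OC)c(-c2cc(-c3ccc(C(=O)N4CCCC4)s3)on2)c1`: > 30000 nM

All three were examined in a functional assay on A549 cells (Homo sapiens) for cytotoxicity, read by XTT assay, with a stated time of 72 h; on this read-out lower numbers stand for stronger inhibition and higher numbers for weaker inhibition. Compound 1 gives only a limit there, and its reading of > 30000 nM is not a number. Compound 2 likewise sits at a limit with > 30000 nM. Compound 3 also returns a limit, > 30000 nM. Compound 1 therefore stands nowhere definite on the scale; the whole set sits at the same boundary, as the limit of > 30000 nM in this assay, at which 3 of the 3 values shown sit, records.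

The step from compound 1 to compound 2, a step that the two limits leave unreadable from compound 1 to compound 2, and the step from compound 2 to compound 3, a step that the two limits leave unreadable from compound 2 to compound 3, both fall between two limits and reveal nothing about size or direction. Compound 4 `O=C1C=CC(=O)C(c2cc(-c3ccc(C(=O)NCC4CC4)s3)on2)=C1` differs from compound 1 by (cyclopropylmethyl)amino in place of 4-(trifluoromethyl)piperidin-1-yl on a carbonyl carbon. Among the measured compounds shown here, the one measured step at the carbonyl carbon, from compound 2 to compound 3, is unreadable, so no direction in this assay can be drawn from the measured compounds, and the most probable outcome for compound 4 is again a limit. Compound 4 is accordingly expected near 30000 nM, between 8000 nM and 100000 nM, a step of a number no higher from compound 1 to compound 4 (the limit leaves the size open) that is estimated, not measured.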

Compound 4, half-maximal inhibitory concentration: > 30000 nM
Compound 4 gave a limit, no number; the forecaster's own chance of this, stated with the estimate: 80%; the middle value sits exactly at the limit.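

Compound 4 also gives only a limit, > 30000 nM, not a number, so no step can be read between compound 1 and compound 4. The compounds shown leave open which change, if any, would bring a measurable value in this assay, as the whole set rests at one boundary: the limit of > 30000 nM in this assay, at which 4 of the 4 values shown sit.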